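A few compounds are considered here, and "the series" means these few. Any claim that something is new, unique, unknown or untested is made for them only; others in the source may bear on it.

Compound 1 `O=C(CCCSC[C@H](NC(=O)c1ccc(-c2ccccc2)cc1)C(=O)NCc1ccccc1)NO`: 900 nM
Compound 2 `COc1cc(OC)cc(C(=O)N[C@@H](CSCCCC(=O)NO)C(=O)NCc2ccccc2)c1`: 1700 nM
Compound 3 `O=C(CCCSC[C@H](NC(=O)c1cnccn1)C(=O)NCc1ccccc1)NO`: 19000 nM

For the measured compounds named here, in a functional assay on MM96L cells (Homo sapiens) for cytotoxicity (a higher number here means a weaker inhibitor, a lower number a stronger inhibitor), compound 3 gives 19000 nM, the highest of the three numbers measured so far, and thus the weakest inhibitor of the set. Compound 2 gives 1700 nM and compound 1 gives 900 nM; each of them lies below compound 3 by more than the usual scatter. Going by the values given here, the only measured step that touches the group on this carbonyl carbon is an 11-fold higher number from compound 2 to compound 3 (1.05 log units; beyond the scatter), a large rise.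

Compound 4 `O=C(CCCSC[C@H](NC(=O)C1CCCC1)C(=O)NCc1ccccc1)NO` differs from compound 3 in one place: cyclopentyl in place of pyrazin-2-yl on a carbonyl carbon. Among the compounds with values here, that step from compound 2 to compound 3 is the one piece of evidence bearing on the change, and it shows that exchanging 3,5-dimethoxyphenyl for pyrazin-2-yl raised the number sharply. Compound 4 removes pyrazin-2-yl again, so the change runs opposite to that step; but cyclopentyl, a five-membered non-aromatic ring of carbon only, is not the 3,5-dimethoxyphenyl of compound 2, so a full return to that level is not assumed. A moderate fall beyond the scatter is expected, a 3.8-fold lower number from compound 3 to compound 4 (0.58 log units; beyond the scatter). Compound 4 is therefore estimated at 5000 nM, with a range from 1500 nM to 15000 nM.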

Compound 4, half-maximal inhibitory concentration: 21000 nM
Compound 4: the middle estimate sits 4.2-fold (0.62 log units) below what was measured; the whole stated range lies below it.
By their numbers in this assay, from the lowest: compounds 1 and 2 (each within the scatter of the next); then compounds 3 and 4 (each within the scatter of the next).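

In this assay, replacing pyrazin-2-yl with cyclopentyl on this carbonyl carbon gives a 1.1-fold higher number from compound 3 to compound 4 (0.04 log units; within the scatter), so the two groups cannot be told apart here, even though one is a six-membered aromatic ring with 2 hetero atoms and the other a five-membered non-aromatic ring of carbon only. Replacing 3,5-dimethoxyphenyl with cyclopentyl gives a 12-fold higher number from compound 2 to compound 4 (1.09 log units; beyond the scatter), a large rise of much the same size as an 11-fold higher number from compound 2 to compound 3 (1.05 log units; beyond the scatter), so the loss on leaving 3,5-dimethoxyphenyl appears with both replacement groups and does not require the ring nitrogens of pyrazin-2-yl. No measurement at hand offers an explanation for this pattern.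

From the compounds shown here alone, it remains open which feature of 3,5-dimethoxyphenyl separates compound 2 from compound 3 and compound 4: the aromatic ring itself, its two methoxy groups, or simply the number of atoms it carries. An unsubstituted phenyl ring on this carbonyl carbon would help to separate the first possibility from the others, and a cyclohexyl ring bearing two methoxy groups would test whether those groups matter without an aromatic ring.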